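Bromo-to-hydroxy swap on the selenium-bound chain, second pair

A few compounds are considered here, and "the series" means these few. Any claim that something is new, unique, unknown or untested is made for them only; others in the source may bear on it.

Measured compounds:
- compound 1 `OCC#CCSc1cnc2ccccc2c1[Se]CC#CCBr`: 2.8 ug/mL
- compound 2 `OCC#CCSc1cnc2ccccc2c1[Se]CC#CCO`: 26.6 ug/mL
- compound 3 `C#CCSc1cnc2ccccc2c1[Se]CC#CCBr`: 2.2 ug/mL

In a functional assay on SW707 cells (Homo sapiens) for cytotoxicity, read by sulforhodamine B assay, with a stated time of 72 h (on this read-out higher numbers stand for weaker inhibition and lower numbers for stronger inhibition), compound 3 shows the lowest of the three numbers. Its nearest neighbour is compound 1, and the step of a 1.3-fold lower number from compound 1 to compound 3 (0.10 log units; within the scatter) sits within the scatter, so the two are not separable. The step of a 9.5-fold higher number from compound 1 to compound 2 (0.98 log units; beyond the scatter) is the only one beyond the scatter so far, and it comes from the same kind of change that is now in question.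

Compound 4 `C#CCSc1cnc2ccccc2c1[Se]CC#CCO` differs from compound 3 as follows: hydroxy in place of bromo on a saturated chain carbon bound to a triple-bonded carbon

The change now in question is the one already seen in a 9.5-fold higher number from compound 1 to compound 2 (0.98 log units; beyond the scatter), where the number rose by a clear margin, and it is repeated here on the core of compound 3. Going by the values given here, no step yet shows this change on a core lacking the hydroxymethyl on the triple-bonded carbon, but the step of a 1.3-fold lower number from compound 1 to compound 3 (0.10 log units; within the scatter) suggests that part of the molecule hardly moves the number. A rise in this assay of about the size seen for compound 1 to compound 2 is therefore expected, i.e. a step of a 9.5-fold higher number from compound 3 to compound 4 (0.98 log units; beyond the scatter) is estimated. For compound 4 an expected value in this assay of 21 ug/mL, with a range from 8 ug/mL to 50 ug/mL, is put down.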

Compound 4, concentration for 50% inhibition: 3.3 ug/mL
Estimate against measurement, compound 4: 6.4-fold (0.80 log units) above, outside the stated range (below it).
By their numbers in this assay, from the lowest: compounds 3, 1 and 4 (each within the scatter of the next); then compound 2.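

In this assay, hydroxy in place of bromo on a saturated chain carbon bound to a triple-bonded carbon gives a 1.5-fold higher number from compound 3 to compound 4 (0.18 log units; within the scatter), so the size of this change depends on the core that carries it: the same change on two cores in this assay, a 9.5-fold higher number (0.98 log units; beyond the scatter) from compound 1 to compound 2 and a 1.5-fold higher number (0.18 log units; within the scatter) from compound 3 to compound 4, 6.3-fold (0.80 log units) apart, beyond the scatter of two such steps

The other change behaves in the same way, since hydrogen in place of hydroxymethyl on a triple-bonded carbon gives an 8.1-fold lower number from compound 2 to compound 4 (0.91 log units; beyond the scatter), a clear step on this core and not on the bromo-bearing one: the same change on two cores in this assay, a 1.3-fold lower number (0.10 log units; within the scatter) from compound 1 to compound 3 and an 8.1-fold lower number (0.91 log units; beyond the scatter) from compound 2 to compound 4, 6.3-fold (0.80 log units) apart, beyond the scatter of two such steps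

Among these four compounds, compound 2 alone carries hydroxymethyl at both chain ends, and the raised number in this assay appears only with that pairing, not with either hydroxymethyl group alone on compound 4 or compound 1.

Going by these compounds, whether this pairing effect is specific to hydroxy remains open, as an amine or a methoxy group in its place on both chains would show whether other groups also raise the number. On these data alone, it is also open whether a longer chain between the triple-bonded carbon and the hydroxy keeps the same dependence on the other chain.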